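The source may hold more compounds than are shown below. What is called first, only, known or untested is meant among the compounds shown, and "the series" means these compounds.

In an in vivo ADME assay on the whole organism (strain 129/SvEvBrd x C57BL/6) for pharmacokinetics, with Mus musculus as the target, at a dose of 1 mg/kg by the intravenous route (on this read-out higher numbers stand for fast clearance and lower numbers for slow clearance), compound 1 `OC[C@@H](O)[C@@H](O)[C@H](O)c1c[nH]c(-c2cnccn2)n1` gives 13.4 mL/min/kg and compound 2 `CC(=O)c1nc([C@@H](O)[C@@H](O)[C@H](O)CO)c[nH]1` gives 18.8 mL/min/kg, so compound 2 stands within the usual scatter of compound 1. Compound 3 `CC(=O)c1nc([C@H](O)[C@@H](O)[C@@H](O)CO)c[nH]1`, not yet measured, departs from compound 2 in one way: the two compounds have the same atoms and bonds and differ only in configuration as drawn: 2 of 3 stereo elements differ; a stereocentre at a saturated chain carbon is drawn R in compound 2 and S in compound 3; a stereocentre at a saturated chain carbon is drawn R in compound 2 and S in compound 3. Among the compounds with values here, no measured pair shows what a change of configuration does here, so no step beyond the scatter is expected in this assay, in either direction, and compound 2 at 18.8 mL/min/kg serves as the anchor. The estimate for compound 3 is 18 mL/min/kg, with an expected range from 9 mL/min/kg to 36 mL/min/kg. This estimate means an expected step of a 1.0-fold lower number from compound 2 to compound 3 (0.02 log units; within the scatter).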

Compound 3, clearance: 6.7 mL/min/kg
Beside the measured number, compound 3's estimate is 2.7-fold (0.43 log units) above it; measured number below the stated range.
By their numbers in this assay, from the lowest: compounds 3, 1 and 2 (each within the scatter of the next, the first and the last beyond it).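

In this assay, changing two stereocentres on the saturated chain from R to S gives a 2.8-fold lower number from compound 2 to compound 3 (0.45 log units; beyond the scatter). Configuration at this chain can therefore move clearance beyond the scatter, which the earlier compounds, with no such pair among them, could not show. The step can be tied to configuration alone because nothing else separates the two structures: the fact that compounds 2 and 3 differ only in the configuration as drawn

Which of the two stereocentres carries the step remains open. Also open, from the compounds shown here alone, is whether the same change would act alike in compound 1, or with an amine or a carboxylic acid in place of the acetyl group.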